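Aryl replacement on the core of compound 1

This account rests on a few compounds, and the source may have more. Where it says the series, first, only, none or still open, it means among the compounds named here.

Compound 1 `CC#C[C@@H](Cc1nnn[nH]1)c1ccc(OCc2ccc3scc(-c4cncnc4C)c3c2)cc1` is the reference point. In an ADME assay on microsomes from liver (Rattus norvegicus) for metabolic stability (a lower number here means that the compound disappears faster, a higher number that the compound lasts longer), compound 1 gives 0.333 h. Compound 3 `CC#C[C@@H](Cc1nnn[nH]1)c1ccc(OCc2ccc3sc(F)c(-c4ccccc4C)c3c2)cc1` gives 0.367 h in this assay, which lies within the scatter of the number for compound 1, so no order between the two is read. Compound 2 `CC#C[C@@H](Cc1nnn[nH]1)c1ccc(OCc2ccc3sc(C(F)(F)F)c(-c4ccc(OCCOC)cc4C)c3c2)cc1` sits at > 3 h in this assay, a limit of the assay and not a number (the limit of > 3 h in this assay, at which 1 of the 3 values shown sits). Within the data shown here, of the two numbers known, compound 1 carries the lower one, with compound 3 inside the scatter of it.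

Compound 4 `CC#C[C@@H](Cc1nnn[nH]1)c1ccc(OCc2ccc3scc(-c4cc(OCCOC)ccc4C)c3c2)cc1` differs from compound 1 in one place: 5-(2-methoxyethoxy)-2-methylphenyl in place of 4-methylpyrimidin-5-yl on an aromatic carbon. The same 2-methoxyethoxy chain appears in compound 2, but compound 2 also carries trifluoromethyl on the core, so the aryl change alone is not isolated by any measured pair. The expected step is a 1.8-fold higher number from compound 1 to compound 4 (0.26 log units; within the scatter), modest and toward a longer half-life, with a real chance of none beyond the scatter. Compound 4 is estimated at 0.6 h in this assay, between 0.25 h and 1.5 h.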

Compound 4, half-life: 0.367 h
For compound 4 the middle estimate is 1.6-fold (0.21 log units) above the measured one; the range from low to high includes it.
By their numbers in this assay, from the lowest: compounds 1, 3 and 4 (each within the scatter of the next). At a limit, above all of these: compound 2.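

At the aromatic carbon two ring bonds from the ring sulfur, 5-(2-methoxyethoxy)-2-methylphenyl in place of 4-methylpyrimidin-5-yl gives a 1.1-fold higher number from compound 1 to compound 4 (0.04 log units; within the scatter) in this assay, so this first single-place pair at the position shows no change in half-life. The ring of carbon only and the 2-methoxyethoxy chain enter together in this step, and neither can be read apart from the other. Nothing measured here gives a cause for this result.

Among these compounds, no single-place pair isolates the trifluoromethyl on the core of compound 2, whose value is a limit of the assay. Also open, on these data alone, is whether an amine or a carboxylic acid in place of the 2-methoxyethoxy chain would give a step beyond the scatter at this position.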